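A few compounds are considered here, and "the series" means these few. Any claim that something is new, unique, unknown or untested is made for them only; others in the source may bear on it.

Compounds measured so far:
compound 1 `CCC(=O)N1CCC(NS(=O)(=O)c2ccc(NC(=O)c3ccccc3C)c3ccccc23)CC1` 2.5 nM
compound 2 `Cc1ccccc1C(=O)Nc1ccc(S(=O)(=O)NC2CCN(C(=O)CN)CC2)c2ccccc12` 4.1 nM
compound 3 `Cc1ccccc1C(=O)Nc1ccc(S(=O)(=O)NC2CCN(C(=O)N3CCCCC3)CC2)c2ccccc12` 4.2 nM

In an assay on L1.2 cells for binding affinity to C-C chemokine receptor type 8 (Homo sapiens) (on this read-out higher numbers stand for weaker inhibition and lower numbers for stronger inhibition), compound 3 stands at the highest of the three numbers, though its steps to the others lie within the scatter: a 1.7-fold higher number from compound 1 to compound 3 (0.23 log units; within the scatter) and a 1.0-fold higher number from compound 2 to compound 3 (0.01 log units; within the scatter). The next compound, compound 4 `Cc1ccccc1C(=O)Nc1ccc(S(=O)(=O)NC2CCN(C(=O)N3CCOCC3)CC2)c2ccccc12`, differs from compound 3 only at the group on the carbonyl carbon: morpholin-4-yl in place of piperidin-1-yl on a carbonyl carbon. Among the measured compounds shown here, no measured step covers this exact exchange; the nearest are the changes at the same position, a 1.7-fold higher number from compound 1 to compound 3 (0.23 log units; within the scatter) and a 1.0-fold higher number from compound 2 to compound 3 (0.01 log units; within the scatter), both within the scatter, which shows this position tolerating varied groups with little shift. On that basis compound 4 is expected to stay close to compound 3, with a step of about a 1.1-fold higher number from compound 3 to compound 4 (0.03 log units; within the scatter), not beyond the scatter. The estimate for compound 4 is therefore 4.5 nM, in the range 2 nM to 10 nM.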

Compound 4, inhibition constant: 6.3 nM
Compound 4: middle estimate off by 1.4-fold (0.15 log units), on the low side, and the stated range covers the measured number.
By their numbers in this assay, from the lowest: compounds 1, 2, 3 and 4 (each within the scatter of the next, the first and the last beyond it).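

In this assay, morpholin-4-yl on the carbonyl carbon stays within the scatter of piperidin-1-yl (a 1.5-fold higher number from compound 3 to compound 4 (0.18 log units; within the scatter)) and of aminomethyl (a 1.5-fold higher number from compound 2 to compound 4 (0.19 log units; within the scatter)). Against ethyl, the same position gives the only step beyond the scatter so far, a modest one (a 2.5-fold higher number from compound 1 to compound 4 (0.40 log units; beyond the scatter)), so exchanges here are not wholly without effect. Nothing available explains this step.

Still open, going by these compounds, is whether a carboxylic acid, a longer alkyl chain or a tertiary amine on this carbonyl carbon would move the number further. Also open, on these data alone, is how changes elsewhere on the shared core compare.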